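Urea aryl replaced by thiazolyl in a weak series

The source may report more compounds than this note shows. Statements on the series, on what has been measured and on what is new or still open speak of the compounds shown alone.

Compound 2 `COc1cccc(NC(=O)Nc2ccc(Nc3ncnc4c3OCCN4)cc2)c1` sits at the top of what has been measured. In a functional assay on BaF3 cells (Mus musculus) for inhibition, read by MTT assay, with a stated time of 3 days (on this read-out lower numbers stand for stronger inhibition of growth and higher numbers for weaker inhibition of growth), compound 2 gives > 10000 nM, which is a limit of the assay and not a number. Compound 1 `O=C(Nc1ccc(Cl)cc1)Nc1ccc(Nc2ncnc3c2OCCN3)cc1` likewise returns only a limit in this assay, > 10000 nM. Compound 3 `O=C(Nc1ccc(Nc2ncnc3c2OCCN3)cc1)Nc1cc(Cl)cc(Cl)c1` gives 10000 nM in this assay. Two of the three values stand at the same limit (the limit of > 10000 nM in this assay, at which 2 of the 3 values shown sit), so none of the three steps among the measured compounds has a readable size: a step that the two limits leave unreadable from compound 1 to compound 2, a number no higher from compound 1 to compound 3 (the limit leaves the size open) and a number no higher from compound 2 to compound 3 (the limit leaves the size open). All three swap one aryl group on the urea nitrogen for another, and none of them shows whether such a swap moves the growth inhibition at all.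

Compound 4 `CC(C)(C)c1csc(NC(=O)Nc2ccc(Nc3ncnc4c3OCCN4)cc2)n1` differs from compound 2 in one place: 4-(tert-butyl)-1,3-thiazol-2-yl in place of 3-methoxyphenyl on an amide-type nitrogen. The measured steps bear on it only insofar as they concern the same position, and they give no direction and no size. Compound 4 is therefore expected to stay near the limit of this assay, with a fair chance of returning only a limit again. The expected step is an at least 1.2-fold lower number from compound 2 to compound 4 (0.09 log units; that floor lies within the scatter), which is not expected to exceed the scatter. Compound 4 is estimated at 8000 nM, within a range from 1500 nM to 30000 nM.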

Compound 4, concentration for 50% growth inhibition: > 10000 nM
Compound 4 was reported as a limit (the forecaster's own chance of this, stated with the estimate: 55%); at least 1.2-fold (0.09 log units) between middle value and limit.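

The 4-(tert-butyl)-1,3-thiazol-2-yl group takes this position from a six-membered aromatic ring of carbon only to a five-membered aromatic ring with 2 hetero atoms, and even this change on the amide-type nitrogen yields no readable value. Compound 3 remains the only one of the four with a number, 10000 nM, and that number comes from another aryl group, not from the thiazolyl group; the swap to the thiazolyl group gives a number no lower from compound 3 to compound 4 (the limit leaves the size open). None of the three new steps to compound 4 can be read, because compound 4 sits at the same limit as compound 1 and compound 2: the limit of > 10000 nM in this assay, at which 3 of the 4 values shown sit.

From the compounds shown here alone, how far the true values of compound 1, compound 2 and compound 4 lie beyond the limit stays open, and with it the size and direction of any change at this position. Also open, going by these compounds, is whether a 2-(piperazin-1-yl)ethyl chain or a carboxyphenyl group on the amide-type nitrogen would give a readable value.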